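A few compounds are considered here, and "the series" means these few. Any claim that something is new, unique, unknown or untested is made for them only; others in the source may bear on it.

Compound 2 `COc1ccc2c(=O)c(/C=C/C(=O)NCc3ccc(F)cc3)coc2c1` carries a 4-fluorobenzyl group on its amide-type nitrogen. In a functional assay on A549 cells (Homo sapiens) for inhibition, read by MTT assay, with a stated time of 48 h (on this read-out higher numbers stand for weaker inhibition and lower numbers for stronger inhibition), compound 2 gives > 100000 nM, which is a limit of the assay rather than a number. Among the measured compounds shown here, the only other measured compound is compound 1 `COc1ccc2c(=O)c(/C=C/C(=O)Nc3cccc(C)c3)coc2c1`, which carries 3-methylphenyl on that nitrogen instead. In this assay compound 1 gives > 100000 nM, again a limit. The step that the two limits leave unreadable from compound 1 to compound 2 therefore has no readable size, and both values sit at the limit of > 100000 nM in this assay, at which 2 of the 2 values shown sit. Compound 3 `COc1ccc(CNC(=O)/C=C/c2coc3cc(OC)ccc3c2=O)cc1` differs from compound 2 by methoxy in place of fluoro on an aromatic carbon. For the measured compounds named here, no measured step bears on this exchange: the single step between the two measured compounds cannot be read, and every value shown is a limit. With nothing but limits at hand, compound 3 is expected most likely to return a limit as well, so the expected step is a number no higher from compound 2 to compound 3 (the limit leaves the size open). Compound 3 is therefore estimated at 100000 nM, with a range from 30000 nM to 300000 nM.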

Compound 3, half-maximal inhibitory concentration: 22500 nM
Compound 3: middle estimate off by 4.4-fold (0.65 log units), on the high side; measured number below the stated range.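

In this assay, among the compounds shown here, the aromatic carbon para to a large group turns out to be a place where a single exchange can bring a number into view, where the earlier compounds gave only limits. Methoxy in place of fluoro there gives an at least 4.4-fold lower number from compound 2 to compound 3 (0.64 log units; beyond the scatter), so this small change, which swaps one heavy atom for two and adds one hydrogen-bond acceptor, is enough to move the read-out beyond the scatter. The change of the whole group on the amide-type nitrogen gives an at least 4.4-fold lower number from compound 1 to compound 3 (0.64 log units; beyond the scatter), while the step from compound 1 to compound 2 cannot be read, and both readable steps give only a smallest possible size because each starts from a limit: the limit of > 100000 nM in this assay, at which 2 of the 3 values shown sit.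

From the compounds shown here alone, the true distance between compound 2 and compound 3 stays open, and with it whether the methoxy group's oxygen or its added carbon matters more for the change. The compounds shown also leave open what a hydroxyl group, an amine or a longer chain such as ethoxy would do on that aromatic carbon, and whether 4-methoxyphenyl directly on the amide-type nitrogen would behave like 4-methoxybenzyl.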